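The source may hold more compounds than are shown below. What is called first, only, known or untested is meant among the compounds shown, and "the series" means these compounds.

Compound 1 `Cc1ccc(NC(=O)Nc2ccc(C)c(S(=O)(=O)N(C)C)c2)cc1Cl` is one of three ureas sharing a common core, each carrying a different aryl group on the second urea nitrogen. In an assay on HEK293 cells for activation of Kir3.1/Kir3.2 (Homo sapiens), read by fluorescence and thallium flux, with a stated time of 4 min (on this read-out higher numbers stand for an effect only at larger amounts of compound and lower numbers for an effect already at smaller amounts), compound 1 gives 2900 nM. This places compound 1 second highest among the three numbers shown: compound 2 `COc1ccc(NC(=O)Nc2ccc(C)c(S(=O)(=O)N(C)C)c2)cc1` gives 1700 nM, and compound 3 `Cc1ccc(NC(=O)Nc2ccccc2F)cc1S(=O)(=O)N(C)C` gives 3900 nM. The step of a 1.7-fold lower number from compound 1 to compound 2 (0.23 log units; within the scatter) and the step of a 1.3-fold higher number from compound 1 to compound 3 (0.13 log units; within the scatter) both stay within the scatter, while the step of a 2.3-fold higher number from compound 2 to compound 3 (0.36 log units; beyond the scatter) is modest. Compound 1 therefore sits among near neighbours rather than apart from them.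

The unmeasured compound 4 `Cc1ccc(NC(=O)Nc2cccc(F)c2)cc1S(=O)(=O)N(C)C` differs from compound 1 only at that aryl group: 3-fluorophenyl in place of 3-chloro-4-methylphenyl on an amide-type nitrogen. Going by the values given here, the two measured exchanges of this same aryl group, from compound 1 to compound 2 and from compound 1 to compound 3, both left the number within the scatter, and even the one step beyond the scatter, from compound 2 to compound 3, was modest. On this basis a 3-fluorophenyl in place of 3-chloro-4-methylphenyl is expected to produce no step beyond the scatter, an expected change of a 1.0-fold higher number from compound 1 to compound 4 (0.01 log units; within the scatter). Compound 4 is accordingly estimated to give 3000 nM, with an expected range from 1200 nM to 7500 nM.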

Compound 4, half-maximal effective concentration: 1100 nM
Compound 4: middle estimate off by 2.7-fold (0.44 log units), on the high side; measured number outside the range, below it.
By their numbers in this assay, from the lowest: compounds 4, 2, 1 and 3 (each within the scatter of the next, the first and the last beyond it).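

In this assay, exchanging the 3-chloro-4-methylphenyl group on the amide-type nitrogen proved able to leave the scatter, which neither earlier exchange of that group had done, giving a 2.6-fold lower number from compound 1 to compound 4 (0.42 log units; beyond the scatter). The two fluorophenyl groups are also not interchangeable at this place: 3-fluorophenyl in place of 2-fluorophenyl gives a 3.5-fold lower number from compound 3 to compound 4 (0.55 log units; beyond the scatter), the largest step among the four compounds, though still a modest one. By contrast, 3-fluorophenyl in place of 4-methoxyphenyl gives a 1.5-fold lower number from compound 2 to compound 4 (0.19 log units; within the scatter), which stays within the scatter, so these two groups cannot be told apart on this read-out.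

The compounds shown leave open whether a 4-fluorophenyl, 3-chlorophenyl or 3-methylphenyl group on this nitrogen would match 3-fluorophenyl or fall nearer 2-fluorophenyl. They also leave open how an aryl group carrying an amine or a carboxylic acid would behave, and what changes to the rest of the shared core, identical in all four compounds, would do.

Nothing among the data shown offers an explanation for these steps.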